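The source may hold more compounds than are shown below. What is called first, only, known or untested is meant among the compounds shown, and "the series" means these compounds.

Compound 1 `C=C[C@@](C)(/C=C/c1ccc(OC(C)=O)cc1)CCC=C(C)C`: 67%
Compound 2 `C=C[C@@](C)(/C=C/c1ccc(OC(=O)CCC)cc1)CCC=C(C)C`: 38%
Compound 3 `C=C[C@@](C)(/C=C/c1ccc(OC)cc1)CCC=C(C)C`: 44%

In a functional assay on PC-3 cells (Homo sapiens) for inhibition, with a stated time of 48 h, tested at 50 uM (on this read-out higher numbers stand for more inhibition of growth at the one concentration tested and lower numbers for less inhibition of growth), compound 3 gives 44%. Its position is set by two steps: a number 23 percentage points lower from compound 1 to compound 3 (beyond the scatter) and a number 6 percentage points higher from compound 2 to compound 3 (within the scatter).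

Compound 4 `COc1ccc(/C=C/[C@](C)(/C=C/c2ccc(O)cc2)CCC=C(C)C)cc1` brings a new kind of change: 2-(4-hydroxyphenyl)ethenyl in place of vinyl on a saturated chain carbon bound to a double-bonded chain carbon and two saturated chain carbons. The vinyl group is replaced, while the measured steps alter only the group on the aromatic oxygen or its chain. The largest of them is a number 29 percentage points lower from compound 1 to compound 2 (beyond the scatter), and a number 23 percentage points lower from compound 1 to compound 3 (beyond the scatter) is close behind. These steps show how far this series can move, but they give no direction for the new change. The expected step, beyond the scatter or not, is therefore small: a number 6 percentage points higher from compound 3 to compound 4 (within the scatter). For compound 4 the estimate is 50%, with an expected range of 25% to 75%.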

Compound 4, percent growth inhibition at one concentration: 93%
Estimate against measurement, compound 4: 43 percentage points below; measured number above the stated range.
By their numbers in this assay, from the lowest: compounds 2 and 3 (each within the scatter of the next); then compound 1; then compound 4.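

Replacing the vinyl group at this position moves the number much further than the earlier modest changes to the group on the aromatic oxygen or its chain: in this assay, there is a number 49 percentage points higher from compound 3 to compound 4 (beyond the scatter), a large step. So this position can tolerate a much larger group, here one with an added aromatic ring and a hydroxyl, without losing growth inhibition. Nothing measured here says why the number rises.

As far as these compounds go, it remains open whether the hydroxyl itself matters, or whether a plain phenyl, an amine or a carboxylic acid on that ring would give a similar number. Also open, from the compounds shown here alone, is how a longer chain at this position would compare.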